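A few compounds are considered here, and "the series" means these few. Any claim that something is new, unique, unknown or untested is made for them only; others in the source may bear on it.

Measured so far in a functional assay on M14 cells (Homo sapiens) for antiproliferative activity, with a stated time of 72 h; on this read-out lower numbers stand for stronger inhibition and higher numbers for weaker inhibition:
compound 1, `C=CC[C@H]1C[C@]2([C@@H](C)Cc3ccccc3)OCOC2=CC1=O`, gives 5100 nM
compound 2, `C=CC[C@H]1C[C@]2([C@@H](C)Cc3ccc(OC)nc3)OCOC2=CC1=O`, gives 180 nM

Compound 2 stands at the lower of the two numbers. Among the measured compounds shown here, it is separated from compound 1 by a 28-fold lower number from compound 1 to compound 2 (1.45 log units; beyond the scatter), a large step well beyond the scatter, and that is the only step recorded. It swaps the whole aromatic group: 6-methoxypyridin-3-yl in place of phenyl on a saturated chain carbon, two bonds along the chain from a saturated ring carbon.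

Compound 3, `C=CC[C@H]1C[C@]2([C@@H](C)Cc3cnc(OC)c(OC)c3)OCOC2=CC1=O`, keeps the ring of compound 2 and differs from it by methoxy in place of hydrogen on an aromatic carbon. For the measured compounds named here, no recorded step bears directly on this change; the only step available concerns the exchange of the aromatic group itself and gives no guide to adding a second methoxy to that ring. With nothing to lean on, the expected change in this assay is none beyond the scatter, a 1.4-fold higher number from compound 2 to compound 3 (0.14 log units; within the scatter), in either direction. Compound 3 is therefore estimated at 250 nM, with a range of 80 nM to 800 nM.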

Compound 3, half-maximal inhibitory concentration: > 20000 nM
Compound 3 gave a limit, no number; the forecaster's own chance of this, stated with the estimate: 0%; middle value at least 80-fold (1.90 log units) away from the limit.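

In this assay, methoxy in place of hydrogen on an aromatic carbon gives an at least 110-fold higher number from compound 2 to compound 3 (2.04 log units; beyond the scatter), so this position, ortho to a methoxy group and two atoms from the ring nitrogen, does not accept the change, although the entering group has only 2 heavy atoms. The earlier step concerned only the exchange of the whole aromatic group, whereas this one shows that the activity of compound 2 depends on how its ring is substituted and not only on which ring is present, and that a single added methoxy is enough to lose it. The value of compound 3 is a limit of the assay and not a number, so the step has no upper end: the limit of > 20000 nM in this assay, at which 1 of the 3 values shown sits.

Open, as far as these compounds go, is whether a fluorine, a methyl or a hydroxyl on this same aromatic carbon would give a similar loss, or whether the loss belongs to the methoxy alone. Also open, from the compounds shown here alone, is whether a methoxy on another carbon of this ring, or on the phenyl of compound 1, would behave in the same way.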